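Aryl ester variation on a flavone scaffold: T-cell inhibition

The source may hold more compounds than are shown below. What is called first, only, known or untested is meant among the compounds shown, and "the series" means these compounds.

Compound 1, `COC(=O)c1cc(O)ccc1OC(=O)COc1cc(O)c2c(=O)cc(-c3ccccc3)oc2c1`, gives 29500 nM in a functional assay on cells (T-cell, Mus musculus, strain BALB/c) for inhibition, read by MTT assay, with a stated time of 72 h; a lower number here means a stronger inhibitor, a higher number a weaker inhibitor.
Compound 2, `COC(=O)c1c(Br)cccc1OC(=O)COc1cc(O)c2c(=O)cc(-c3ccccc3)oc2c1`, gives 41700 nM in this assay.
Compound 3, `COC(=O)c1cccc(Cl)c1OC(=O)COc1cc(O)c2c(=O)cc(-c3ccccc3)oc2c1`, gives 38700 nM in this assay.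

All three numbers sit close together. Compound 3 stands with compound 2 nearest, a 1.1-fold lower number from compound 2 to compound 3 (0.03 log units; within the scatter), and compound 1 furthest, a 1.3-fold higher number from compound 1 to compound 3 (0.12 log units; within the scatter); neither gap exceeds the scatter.

Compound 4, `COC(=O)c1cc(Br)ccc1OC(=O)COc1cc(O)c2c(=O)cc(-c3ccccc3)oc2c1`, is not yet measured. It differs from compound 3 as follows: 4-bromo-2-(methoxycarbonyl)phenyl in place of 2-chloro-6-(methoxycarbonyl)phenyl on an oxygen next to a carbonyl group

The bearing steps are those in which the aryl ester was exchanged: a 1.4-fold higher number from compound 1 to compound 2 (0.15 log units; within the scatter), a 1.3-fold higher number from compound 1 to compound 3 (0.12 log units; within the scatter) and a 1.1-fold lower number from compound 2 to compound 3 (0.03 log units; within the scatter). Each of them stayed within the scatter, whether the substituent was hydroxy, bromine or chlorine and wherever it sat on the ring. There is therefore no basis for expecting a step beyond the scatter in this assay in either direction. The expected step is a 1.0-fold lower number from compound 3 to compound 4 (0.01 log units; within the scatter). Compound 4 is estimated at 38000 nM, with a range from 19000 nM to 76000 nM.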

Compound 4, half-maximal inhibitory concentration: 780 nM
Beside the measured number, compound 4's estimate is 49-fold (1.69 log units) above it; the measured number lies below the stated range.
By their numbers in this assay, from the lowest: compound 4; then compounds 1, 3 and 2 (each within the scatter of the next).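

In this assay, the aryl ester on the oxygen next to a carbonyl group no longer looks insensitive to change: 4-bromo-2-(methoxycarbonyl)phenyl in place of 2-chloro-6-(methoxycarbonyl)phenyl gives a 50-fold lower number from compound 3 to compound 4 (1.70 log units; beyond the scatter). Bromine on the ring is not enough by itself, since compound 2 also carries one and the step is a 53-fold lower number from compound 2 to compound 4 (1.73 log units; beyond the scatter), so within this pair the placement of the bromine decides the outcome. Bromo in place of hydroxy on one aromatic carbon gives a 38-fold lower number from compound 1 to compound 4 (1.58 log units; beyond the scatter), so at that carbon the identity of the substituent matters as well.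

Nothing measured here explains why the number falls so far. Going by these compounds, it remains open whether an amine or a carboxylic acid on that same aromatic carbon would keep the number as low as that of compound 4.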